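A few compounds are considered here, and "the series" means these few. Any claim that something is new, unique, unknown or untested is made for them only; others in the source may bear on it.

Compound 3 `CCCCN1CCN(CCCCn2c3c(c4ccccc42)C(=O)c2c[n+]([O-])c4ccccc4c2C3=O)CC1` is the weakest inhibitor of the three measured compounds in a functional assay on HCT-116 cells (Homo sapiens) for cytotoxicity, read by MTT assay, with a stated time of 72 h (a lower number here means a stronger inhibitor, a higher number a weaker inhibitor), where compound 3 gives 1920 nM. Compound 2 `CCCN1CCN(CCCCn2c3c(c4ccccc42)C(=O)c2c[n+]([O-])c4ccccc4c2C3=O)CC1` gives 790 nM, and compound 1 `CN(C)CCCCn1c2c(c3ccccc31)C(=O)c1c[n+]([O-])c3ccccc3c1C2=O` gives 450 nM. The steps of a 2.4-fold higher number from compound 2 to compound 3 (0.39 log units; beyond the scatter) and a 4.3-fold higher number from compound 1 to compound 3 (0.63 log units; beyond the scatter) both lie beyond the scatter, so compound 3 stands at the top of the range on its own. Compound 4 `O=C1c2c[n+]([O-])c3ccccc3c2C(=O)c2c1c1ccccc1n2CCCCn1ccnc1` has not yet been tested. It differs from compound 3 in a single place: 1H-imidazol-1-yl in place of 4-butylpiperazin-1-yl on a saturated chain carbon, four bonds along the chain from an aromatic nitrogen. The measured steps that bear on this position are a 1.8-fold higher number from compound 1 to compound 2 (0.24 log units; within the scatter), a 4.3-fold higher number from compound 1 to compound 3 (0.63 log units; beyond the scatter) and a 2.4-fold higher number from compound 2 to compound 3 (0.39 log units; beyond the scatter), each an exchange of the group on the same chain carbon, and none of them moved the number by more than a modest amount. Among the compounds with values here, no measured pair contains the 1H-imidazol-1-yl group, so its own effect is unknown, and the expectation is a step of similar modest size, a 2.1-fold lower number from compound 3 to compound 4 (0.33 log units; beyond the scatter), probably back toward the numbers of compound 1 and compound 2. Compound 4 is therefore estimated at 900 nM, with a range from 300 nM to 2700 nM.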

Compound 4, half-maximal inhibitory concentration: 240 nM
Compound 4: middle estimate off by 3.8-fold (0.57 log units), on the high side; measured number outside the range, below it.
By their numbers in this assay, from the lowest: compounds 4, 1 and 2 (each within the scatter of the next, the first and the last beyond it); then compound 3.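

In this assay the group on this chain carbon can move the number further than any earlier exchange did: the step is an 8.0-fold lower number from compound 3 to compound 4 (0.90 log units; beyond the scatter) and it is the largest seen at this position. The shorter piperazine partner points the same way with a 3.3-fold lower number from compound 2 to compound 4 (0.52 log units; beyond the scatter) as its step. Against dimethylamino the result differs: a 1.9-fold lower number from compound 1 to compound 4 (0.27 log units; within the scatter) stays within the scatter, so 1H-imidazol-1-yl and dimethylamino cannot be told apart here.

Still open, going by these compounds, is whether a pyrazole, triazole or morpholine ring in this place would give a number like that of 1H-imidazol-1-yl, and whether a shorter chain to the core would keep it. Nothing measured here explains why the number changes with these exchanges.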